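A Methylsulfanyl Side Chain on Compound 2

The compounds below may be only part of what the source reports. "The series", "measured", "known", "first", "only" and "open" are said of these compounds alone.

Measured in a functional assay on MCF7 cells (Homo sapiens) for antiproliferative activity; on this read-out higher numbers stand for weaker inhibition and lower numbers for stronger inhibition:
- compound 1 `Cc1ccc(C(=O)Nc2ccc(O)c3c(=O)cc(-c4ccccc4Cl)oc23)cc1`: 10000 nM
- compound 2 `C[C@@H](NC(=O)OC(C)(C)C)C(=O)Nc1ccc(O)c2c(=O)cc(-c3ccccc3Cl)oc12`: 5500 nM

Only these two values are known so far, and they lie within the scatter of each other, so compound 2 does not stand apart from compound 1. Compound 3 `CSCC[C@@H](NC(=O)OC(C)(C)C)C(=O)Nc1ccc(O)c2c(=O)cc(-c3ccccc3Cl)oc12` is the next analogue, and its difference from compound 2 is (methylsulfanyl)methyl in place of hydrogen on a saturated chain carbon, two bonds along the chain from an amide-type nitrogen and a carbonyl carbon. In words, (methylsulfanyl)methyl replaces hydrogen on a saturated chain carbon, two bonds along the chain from an amide-type nitrogen and a carbonyl carbon. For the measured compounds named here, no measured step touches that place. Going by the values given here, the one measured step, a 1.8-fold lower number from compound 1 to compound 2 (0.26 log units; within the scatter), exchanged a different group and stayed within the scatter, so no step beyond the scatter is expected in this assay. The expected step is a 1.1-fold lower number from compound 2 to compound 3 (0.04 log units; within the scatter). For compound 3 the estimated value is 5000 nM, with an expected range of 2000 nM to 12000 nM.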

Compound 3, half-maximal inhibitory concentration: 2800 nM
The estimate for compound 3 lay 1.8-fold (0.25 log units) above the measured number; measured number inside the range.
By their numbers in this assay, from the lowest: compounds 3, 2 and 1 (each within the scatter of the next, the first and the last beyond it).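

In this assay, for the compounds shown here, the step at this saturated chain carbon, a 2.0-fold lower number from compound 2 to compound 3 (0.29 log units; within the scatter), is the first measured change at this place, and it stays within the scatter. The carbon therefore carries (methylsulfanyl)methyl in place of hydrogen, with its added carbon atoms and sulfur atom, without a change that this read-out can separate from repeat variation, and compound 3 cannot be ranked against compound 2. Nothing available offers an explanation for this step.

The compounds shown leave open whether the sulfur atom matters at all, since a plain ethyl or propyl chain at this carbon would be needed to tell it apart from chain length alone. They also leave open whether a primary amine or a carboxylic acid on that chain would produce a step beyond the scatter.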